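Furan for thiophene on the shared core: working notes

A few compounds are considered here, and "the series" means these few. Any claim that something is new, unique, unknown or untested is made for them only; others in the source may bear on it.

Measured so far:
compound 1 `CCOC(=O)C1=C(C(F)(F)F)NC(=O)NC1c1ccsc1`: 32%
compound 2 `CC1=C(C(=O)OCC(F)(F)F)C(c2ccsc2)NC(=O)N1`: 2%
compound 3 `CC1=C(C(=O)OCC(F)(F)F)C(c2ccoc2)NC(=O)N1`: 13%

All three numbers come from an assay on cells for displacement of a labelled ligand from adenosine receptor A1 (Homo sapiens), read by radioligand binding, with a stated time of 60 min, tested at 1 uM; a higher number here means more inhibition at the concentration tested (going by the name of the read-out), a lower number less inhibition. Compound 1 stands highest of the three, with both others beyond the scatter below it: compound 3 is nearest, compound 2 furthest. Compound 1 and compound 2 are built from the same atoms joined differently; the difference between the two cores is not broken down here. Compound 2 and compound 3 differ by furan-3-yl in place of thiophen-3-yl on a saturated ring carbon, and that change gave a number 11 percentage points higher from compound 2 to compound 3 (beyond the scatter).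

Compound 4 `CCOC(=O)C1=C(C(F)(F)F)NC(=O)NC1c1ccoc1` is not yet measured. It differs from compound 1 by furan-3-yl in place of thiophen-3-yl on a saturated ring carbon. This is the same kind of change as from compound 2 to compound 3, not the same: in compound 1 the saturated ring carbon is next to the ring atom that bears an ethoxycarbonyl group and two ring bonds from the ring atom that bears a trifluoromethyl group, whereas in compound 2 it is next to the ring atom that bears a group of 8 heavy atoms and two ring bonds from the ring atom that bears a methyl group.

For the measured compounds named here, for compound 4 the step in this assay is expected to be a number 9 percentage points higher from compound 1 to compound 4 (within the scatter), resting on the single earlier step of a number 11 percentage points higher from compound 2 to compound 3 (beyond the scatter) and on the higher starting point of compound 1, 32%. The change has been seen only once, on a different core, so the range is kept wide. Compound 4 is estimated at 41%, between 27% and 56%.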

Compound 4, a percentage reported as inhibition, at one concentration (the size of the read-out at that concentration, not a potency): 37%
Compound 4: middle estimate off by 4 percentage points, on the high side; the range from low to high includes it.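

On the core of compound 1, furan-3-yl in place of thiophen-3-yl on a saturated ring carbon gives, in this assay, a number 5 percentage points higher from compound 1 to compound 4 (within the scatter). Set beside the earlier step, the two cores do not separate for this change: the same change on two cores in this assay, a number 11 percentage points higher (beyond the scatter) from compound 2 to compound 3 and a number 5 percentage points higher (within the scatter) from compound 1 to compound 4, 6 percentage points apart, within the scatter of two such steps. The swap therefore carries across these two cores with no difference in step size that stands out from the scatter, but two steps, one of them within the scatter, do not show that furan-3-yl dependably raises the number or that the step would hold on a third core, and readings at one concentration give no potency.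

The compounds shown carry only thiophen-3-yl or furan-3-yl on the saturated ring carbon, so what a phenyl ring or a longer alkyl chain would do at that place stays open. Also open is how the ethoxycarbonyl group and the trifluoromethyl group each act alone, as they appear only together here and the steps shown do not separate them.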